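The compounds below may be only part of what the source reports. "The series", "measured", "known", "first", "only" and "open" are said of these compounds alone.

Of the compounds shown here, three that share one core have been tested in an assay on HEK293 cells for inhibition of Fatty-acid amide hydrolase 1 (Homo sapiens), read by fluorescence; a higher number here means a weaker inhibitor, a lower number a stronger inhibitor. Compound 1 `Cn1ccc2cc(-c3ccc4oc(NC5CCCCC5)nc4c3)ccc21` gives 911 nM and compound 2 `Cn1ccc2cc(-c3ccc4oc(Nc5ccccn5)nc4c3)ccc21` gives 186 nM. On these data alone, compound 3 `CNc1nc2cc(-c3ccc4c(ccn4C)c3)ccc2o1` reaches only a limit of the assay, > 1000 nM, so its exact number is unknown. Compound 4 `Cn1ccc2cc(-c3ccc4oc(N5CCNCC5)nc4c3)ccc21` has not yet been measured; it differs from compound 3 in that (piperazin-1-yl in place of methylamino on an aromatic carbon). Two measured steps end at compound 3: an at least 1.0-fold higher number from compound 1 to compound 3 (0.04 log units; that floor lies within the scatter), and an at least 5.3-fold higher number from compound 2 to compound 3 (0.73 log units; beyond the scatter); both replaced a larger group on the nitrogen with methyl, and the pyridin-2-yl partner sat clearly lower, while compound 3 is known only through (the limit of > 1000 nM in this assay, at which 1 of the 3 values shown sits). The piperazin-1-yl ring repeats neither of those groups, so the expected step that the limit leaves unreadable from compound 3 to compound 4 is uncertain. Compound 4 is estimated at 1500 nM, within 300 nM to 8000 nM.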

Compound 4, half-maximal inhibitory concentration: > 1000 nM
Compound 4 ended at the assay's limit; the forecaster's own chance of this, stated with the estimate: 55%; the middle value lies beyond the limit too.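

In this assay, piperazin-1-yl on this aromatic carbon does not hold the level reached with (pyridin-2-yl)amino, giving an at least 5.3-fold higher number from compound 2 to compound 4 (0.73 log units; beyond the scatter). Against cyclohexylamino it gives an at least 1.0-fold higher number from compound 1 to compound 4 (0.04 log units; that floor lies within the scatter), so no difference from that group can be claimed. The value of compound 4 is a limit, and the steps between compound 3 and compound 4 cannot be read: the limit of > 1000 nM in this assay, at which 2 of the 4 values shown sit.

On these data alone, whether a phenylamino group at this position would keep the level of compound 2 stays open. So does how far past the limit compound 3 and compound 4 actually lie.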